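One ring swap in a growth inhibition series

The compounds below may be only part of what the source reports. "The series", "measured", "known", "first", "only" and "open" are said of these compounds alone.

compound 1 `O=C(/C(=C\c1ccc(Br)c(O)c1)S(=O)(=O)c1ccc(Br)cc1)c1ccc(Br)cc1` gives 50000 nM
compound 2 `COc1ccccc1/C=C(/Sc1ccc(C)cc1)C(=O)c1ccc(Br)cc1` gives 9000 nM
compound 3 `COc1ccc(S/C(=C/c2ccc(Cl)cc2Cl)C(=O)c2ccc(Br)cc2)cc1` gives 1000 nM

In a functional assay on DU-145 cells (Homo sapiens) for inhibition, read by trypan blue exclusion, with a stated time of 96 h (a higher number here means a weaker inhibitor of growth, a lower number a stronger inhibitor of growth), compound 1 stands at 50000 nM as the highest of the three numbers and so the weakest inhibitor of growth among them, with compound 2 and compound 3 both lower by more than the scatter. Compound 4 `O=C(/C(=C\c1ccc(Cl)cc1Cl)S(=O)(=O)c1ccc(Br)cc1)c1ccc(Br)cc1` has not yet been measured. It keeps the rest of compound 1 and changes one group, as follows: 2,4-dichlorophenyl in place of 4-bromo-3-hydroxyphenyl on a double-bonded chain carbon bound to a double-bonded chain carbon with 2,4-dichlorophenyl in place of 4-bromo-3-hydroxyphenyl on a double-bonded chain carbon bound to a double-bonded chain carbon. Among the measured compounds shown here, no measured pair differs in only one place, so this change has no direct precedent. For the measured compounds named here, the only guide is compound 3 at 1000 nM as the lowest number of the three, which also carries 2,4-dichlorophenyl but differs from compound 4 elsewhere. The estimated step is a fall in the number a 10-fold lower number from compound 1 to compound 4 (1.00 log units; beyond the scatter) and is expected to lie beyond the scatter. For compound 4 the estimate is 5000 nM with an expected range of 1200 nM to 25000 nM in this measurement.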

Compound 4, concentration for 50% growth inhibition: 10000 nM
Beside the measured number, compound 4's estimate is 2.0-fold (0.30 log units) below it; low and high end bracket the measured number.
By their numbers in this assay, from the lowest: compound 3; then compounds 2 and 4 (each within the scatter of the next); then compound 1.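

In this assay, putting 2,4-dichlorophenyl in place of 4-bromo-3-hydroxyphenyl on a double-bonded chain carbon bound to a double-bonded chain carbon gives a 5.0-fold lower number from compound 1 to compound 4 (0.70 log units; beyond the scatter), the only one-place comparison among these compounds and a modest step beyond the scatter. At this position, then, growth inhibition is retained and somewhat stronger with a group that carries no hydrogen-bond donors or acceptors in place of one that carries both. Nothing available explains this step.

The swap changes the hydroxy group, the bromine and both chlorines at once, so the compounds shown do not separate their contributions. As far as these compounds go, how an amine or a carboxylic acid on this ring would behave also remains open.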